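The compounds below may be only part of what the source reports. "The series", "measured", "known", "first", "only" and "open" are said of these compounds alone.

Measured compounds:
Compound 1, `COC(=O)Nc1cc(-c2ccc(OC[C@@](C)(N)CC(C)C)c(C)c2)ccn1`, gives 0.8 nM in an assay on isolated protein for inhibition of AP2-associated protein kinase 1 (Homo sapiens), with a stated time of 3 h, in the presence of a further agent that is not named here; a higher number here means a weaker inhibitor, a lower number a stronger inhibitor.
Compound 2, `COC(=O)Nc1cc(-c2cc(Cl)c(OC[C@@](C)(N)CC(C)C)cn2)ccn1`, gives 1.1 nM in this assay.
Compound 3, `COC(=O)Nc1cc(-c2cnc(OC[C@@](C)(N)CC(C)C)c(OC)c2)ccn1`, gives 3.8 nM in this assay.

Among these three numbers compound 1 has the lowest. Compound 2 stands close to it, within the usual scatter of repeated measurements, so the two cannot be told apart on these data. Compound 3 gives a higher number than compound 1, and that gap lies beyond the scatter.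

The next compound, compound 4, `COC(=O)Nc1cc(-c2ccc(OC[C@@](C)(N)CC(C)C)c(C)c2C)ccn1`, is built from compound 1 by a single change: methyl in place of hydrogen on an aromatic carbon. The new methyl sits on an aromatic carbon of a six-membered aromatic ring of carbon only, meta to the (2-amino-2,4-dimethylpentyl)oxy group, and the rest of the molecule is kept unchanged.

Among the measured compounds shown here, no pair of measured compounds shows this exact change, so there is no measured step to lean on. With only one carbon added, the expected step in this assay is small, most likely none beyond the scatter, with perhaps a slight drift to a higher number. The estimate for compound 4 is 1.3 nM, ranging from 0.4 nM to 4 nM, which would be a step of a 1.6-fold higher number from compound 1 to compound 4 (0.21 log units; within the scatter).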

Compound 4, half-maximal inhibitory concentration: 4.5 nM
The estimate for compound 4 lay 3.5-fold (0.54 log units) below the measured number; measured number outside the range, above it.
By their numbers in this assay, from the lowest: compounds 1 and 2 (each within the scatter of the next); then compounds 3 and 4 (each within the scatter of the next).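

This is the only step shown between compounds that differ in one place, and it shows that this position on the carbon-only aromatic ring is sensitive to even a single added carbon: in this assay, the new methyl gives a 5.6-fold higher number from compound 1 to compound 4 (0.75 log units; beyond the scatter), a modest step but one beyond the scatter. A change as small as methyl for hydrogen, ortho to a large group and ortho to a methyl group, is therefore enough to weaken inhibition here. Nothing measured here bears on why the number rises.

Going by these compounds, it remains open whether this carbon disfavours any replacement of hydrogen or only methyl, and a fluorine or a hydroxyl group at the same place would help to answer that. On these data alone, whether a longer chain such as ethyl would move the number further also remains unknown.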